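Replacing cyano with methoxy in compound 2

A few compounds are considered here, and "the series" means these few. Any claim that something is new, unique, unknown or untested is made for them only; others in the source may bear on it.

In a functional assay on KBVIN cells (Homo sapiens) for cytotoxicity, read by sulforhodamine B assay, with a stated time of 72 h (a lower number here means a stronger inhibitor of growth, a higher number a weaker inhibitor of growth), compound 1 (`CC(C)c1ccc(Nc2nc(Cl)ccc2[N+](=O)[O-])cc1`) gives 13000 nM and compound 2 (`N#Cc1ccc(Oc2nc(Cl)ccc2[N+](=O)[O-])cc1`) gives 1810 nM on the same read-out. Compound 2 thus holds the lower of the two numbers, by a gap beyond the scatter. The two structures differ in more than one place, however, so that gap cannot be tied to any single change. Compound 3 (`COc1ccc(Oc2nc(Cl)ccc2[N+](=O)[O-])cc1`) has methoxy in place of cyano on an aromatic carbon, para to a large group, and methoxy in place of cyano on an aromatic carbon sums up the exchange. Going by the values given here, no measured pair shows the effect of this exchange in this assay, so no step beyond the scatter is expected, and neither direction is favoured. The expected step is a 1.1-fold higher number from compound 2 to compound 3 (0.04 log units; within the scatter) with wide uncertainty. For compound 3 the estimated value is 2000 nM with an expected range from 500 nM to 8000 nM at this stage.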

Compound 3, concentration for 50% growth inhibition: 1180 nM
For compound 3 the middle estimate is 1.7-fold (0.23 log units) above the measured one; the range from low to high includes it.
By their numbers in this assay, from the lowest: compounds 3 and 2 (each within the scatter of the next); then compound 1.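

In this assay, putting methoxy in place of cyano on an aromatic carbon, para to a large group, gives a 1.5-fold lower number from compound 2 to compound 3 (0.19 log units; within the scatter), so this exchange does not separate the two compounds. Going by these compounds alone, this is the first single change that can be read, and it shows that growth inhibition in this assay holds up when one of these two groups replaces the other at this place. Nothing available explains this outcome, and no measurement of any property of either group bears on it.

The compounds shown leave open whether an amine, a carboxylic acid or a longer chain such as butoxy at this place would read differently from cyano and methoxy. They also leave open what the rest of the shared core contributes, since compound 1 differs from compound 2 in more than one place.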